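Working notes: compound 4 against the measured set

The source may report more compounds than this note shows. Statements on the series, on what has been measured and on what is new or still open speak of the compounds shown alone.

Measured in a functional assay on K562 cells (Homo sapiens) for antiproliferative activity, read by MTT assay, with a stated time of 72 h; on this read-out lower numbers stand for stronger inhibition and higher numbers for weaker inhibition:
compound 1, `COc1cc(-n2ncnc2-c2ccc(C)cc2)cc(OC)c1OC`, gives only the limit > 10000 nM.
compound 2, `COc1cc(-c2ncnn2-c2ccc([N+](=O)[O-])cc2)cc(OC)c1OC`, gives only the limit > 10000 nM.
compound 3, `COc1cc(-c2ncnn2-c2ccc(N)cc2)cc(OC)c1OC`, gives only the limit > 10000 nM.

Compound 1 stands at a limit, not at a number, in this assay. The same holds for the two companions: the limit of > 10000 nM in this assay, at which 3 of the 3 values shown sit. Among the measured compounds shown here, the one single-point step among them, a step that the two limits leave unreadable from compound 2 to compound 3, is amino in place of nitro on an aromatic carbon, and both ends being limits it is unreadable in size and direction.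

Compound 4, `COc1cc(-n2ncnc2-c2cccc(Cl)c2)cc(OC)c1OC`, differs from compound 1 by 3-chlorophenyl in place of 4-methylphenyl on an aromatic carbon. For the measured compounds named here, no measured step touches this position, and the only step there is gives no readable size, so nothing in the set points to a gain beyond the scatter. Compound 4 is therefore expected to sit at the limit as well, with the step that the limit leaves unreadable from compound 1 to compound 4 expected to be none beyond the scatter. The estimate for compound 4 is 15000 nM, in a range from 5000 nM to 50000 nM.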

Compound 4, half-maximal inhibitory concentration: > 10000 nM
Compound 4 was reported as a limit; the forecaster's own chance of this, stated with the estimate: 80%; the middle value is on the limit's open side.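

The step from compound 1 to compound 4 cannot be read, since both ends are limits and not numbers, and the series stays at one limit: the limit of > 10000 nM in this assay, at which 4 of the 4 values shown sit.

The compounds shown leave open whether 3-chlorophenyl and 4-methylphenyl differ at all, and whether any change to the shared core gives a number rather than a limit.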